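The source may report more compounds than this note shows. Statements on the series, on what has been measured and on what is new or still open speak of the compounds shown alone.

Measured compounds:
- compound 1, `Cc1ccc(S/C(=C/c2ccc(Br)cc2)C(=O)c2ccc(Cl)cc2)cc1`, gives 25000 nM in a functional assay on DU-145 cells (Homo sapiens) for inhibition, read by trypan blue exclusion, with a stated time of 96 h; on this read-out lower numbers stand for stronger inhibition of growth and higher numbers for weaker inhibition of growth
- compound 2, `O=C(/C(=C\c1ccc(O)cc1O)Sc1ccc(Br)cc1)c1ccc(Cl)cc1`, gives 50000 nM in this assay
- compound 3, `O=C(/C(=C\c1ccc(O)cc1O)Sc1ccccc1Br)c1ccc(Cl)cc1`, gives 50000 nM in this assay

Compound 2 stands level with compound 3, the two together at the high end of the three numbers; compound 1 sits lower, but within the scatter of compound 2, so no order among the three is established.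

Going by the values given here, the one measured step, no change at the digits printed from compound 2 to compound 3 (within the scatter), concerns the bromophenyl on the sulfur and does not touch the position changed here.

Compound 4, `O=C(/C(=C\c1ccc(Br)cc1)Sc1ccc(Br)cc1)c1ccc(Cl)cc1`, differs from compound 2 as follows: 4-bromophenyl in place of 2,4-dihydroxyphenyl on a double-bonded chain carbon bound to a double-bonded chain carbon. Among the compounds with values here, no measured pair isolates this change. Compound 1 also carries 4-bromophenyl on the double-bonded chain carbon, yet it differs from compound 2 in a second place, so the values of compound 1 and compound 2 show only that the two lie within the scatter of each other. The step of a 1.7-fold lower number from compound 2 to compound 4 (0.22 log units; within the scatter) is therefore expected to stay within the scatter, in either direction. Compound 4 is estimated at 30000 nM, range 12000 nM to 75000 nM.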

Compound 4, concentration for 50% growth inhibition: 1000 nM
Compound 4: middle estimate off by 30-fold (1.48 log units), on the high side, outside the stated range (below it).
By their numbers in this assay, from the lowest: compound 4; then compounds 1, 2 and 3 (each within the scatter of the next).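

In this assay, going by these compounds alone, the place on the double-bonded chain carbon proves sensitive: 4-bromophenyl in place of 2,4-dihydroxyphenyl gives a 50-fold lower number from compound 2 to compound 4 (1.70 log units; beyond the scatter), whereas the earlier compounds showed no separation beyond the scatter. With 4-bromophenyl held at that place, bromo in place of methyl on an aromatic carbon gives a 25-fold lower number from compound 1 to compound 4 (1.40 log units; beyond the scatter), so the lower number of compound 4 depends on both groups in this pair of comparisons. No measurement on hand accounts for either step.

The compounds shown do not separate loss of the two hydroxy groups from entry of the bromine, a question that plain phenyl or a single hydroxy group at the same place would address. From the compounds shown here alone, it also remains open whether chloro or methoxy in place of the bromo on the aromatic carbon would hold the number of compound 4.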